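A pyridin-2-yl swap on a fast-cleared compound

The source may report more compounds than this note shows. Statements on the series, on what has been measured and on what is new or still open speak of the compounds shown alone.

Compound 1 `COc1ccc(F)cc1N1C(=O)CSC1c1cccc(C(=O)NCCCCn2cccn2)c1` gives 1310 mL.min-1.g-1
Compound 2 `Cc1cccc(N2C(=O)CSC2c2cccc(C(=O)NCCCCc3ccccc3)c2)c1` gives 2940 mL.min-1.g-1

In an ADME assay on microsomes from liver (Mus musculus) for metabolic stability, read by LC-MS, using NADPH, with a stated time of 10 min, tested at 0.1 uM (on this read-out lower numbers stand for slow clearance and higher numbers for fast clearance), compound 2 stands highest of the two at 2940 mL.min-1.g-1 and compound 1 sits lower at 1310 mL.min-1.g-1, a gap beyond the usual scatter. Compound 3 `O=C(NCCCCc1ccccc1)c1cccc(C2SCC(=O)N2c2ccccn2)c1` has pyridin-2-yl in place of 3-methylphenyl on an amide-type nitrogen in a ring. Going by the values given here, no measured pair shows this change alone, so the expected size is a judgement. In this assay a modest drop is expected, estimated as a 2.3-fold lower number from compound 2 to compound 3 (0.35 log units; beyond the scatter) and only just beyond the scatter. For compound 3 the expected value is 1300 mL.min-1.g-1 (estimated range 600 mL.min-1.g-1 to 2700 mL.min-1.g-1).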

Compound 3, intrinsic clearance in microsomes: 644 mL.min-1.g-1
Beside the measured number, compound 3's estimate is 2.0-fold (0.31 log units) above it; low and high end bracket the measured number.
By their numbers in this assay, from the lowest: compound 3; then compound 1; then compound 2.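

Putting pyridin-2-yl in place of 3-methylphenyl on the amide-type nitrogen in a ring gives a 4.6-fold lower number from compound 2 to compound 3 (0.66 log units; beyond the scatter) in this assay and is the first change in a single place shown in this series. It shows that this one position alone can shift the clearance number by more than the usual scatter, and that replacing a ring carbon unit with a ring nitrogen need not leave clearance unchanged.

From the compounds shown here alone, whether pyridin-3-yl or a cyclohexyl group at this position would give a lower or higher number remains open. Nothing measured here gives a reason for the drop.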